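A few compounds are considered here, and "the series" means these few. Any claim that something is new, unique, unknown or untested is made for them only; others in the source may bear on it.

Compound 2, `CC(C)=CCn1cnc2c(Nc3cccc(Cl)c3)nc(N[C@H]3CC[C@H](N)CC3)nc21`, was tested in a functional assay on MCF7 cells (Homo sapiens) for inhibition, read by fluorescence, with a stated time of 72 h (a lower number here means a stronger inhibitor of growth, a higher number a weaker inhibitor of growth), where compound 2 gave 4200 nM. Compound 1, `CC(C)CCn1cnc2c(NCc3cccc(Cl)c3)nc(N[C@H]3CC[C@H](N)CC3)nc21`, also measured in this assay, gave 4700 nM. Going by the values given here, of the two numbers so far, that of compound 2 is the lower one, but compound 1 lies within the scatter of it, so the two cannot be ranked against each other. Among the compounds with values here, compound 1 and compound 2 differ in more than one place, and no single step joins them.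

Compound 3, `CC(C)CCn1cnc2c(Nc3cccc(Cl)c3)nc(N[C@H]3CC[C@H](N)CC3)nc21`, has not yet been measured in this assay. Compound 3 differs from compound 2 in a single spot: isobutyl in place of 2-methylprop-1-en-1-yl on a saturated chain carbon bound to an aromatic nitrogen. The saturated chain that enters is the same one carried by compound 1, which sits close to compound 2 in this assay. Within the data shown here, with no measured step of this kind, the expectation for compound 3 rests on that likeness alone: the change from compound 2 to compound 3 is expected to be a 1.1-fold higher number from compound 2 to compound 3 (0.03 log units; within the scatter), that is, no step beyond the scatter in either direction. For compound 3 in this assay, the estimate is 4500 nM, with a range from 1500 nM to 14000 nM.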

Compound 3, concentration for 50% growth inhibition: 2100 nM
For compound 3 the middle estimate is 2.1-fold (0.33 log units) above the measured one; the range from low to high includes it.
By their numbers in this assay, from the lowest: compounds 3, 2 and 1 (each within the scatter of the next, the first and the last beyond it).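

In this assay, isopentyl in place of 3-methylbut-2-en-1-yl, a change that removes the one chain double bond, gives a 2.0-fold lower number from compound 2 to compound 3 (0.30 log units; within the scatter), so on this saturated chain carbon bound to an aromatic nitrogen the double bond shows no effect that can be told from the scatter. Going by these compounds alone, compound 3 also joins compound 1 and compound 2, which no single step linked before, and on a nitrogen on an aromatic ring, 3-chlorophenyl in place of 3-chlorobenzyl gives a 2.2-fold lower number from compound 1 to compound 3 (0.35 log units; beyond the scatter), the only step here beyond the scatter and a modest one that rests on a single pair. Nothing accompanying these numbers accounts for the size of either step.

On these data alone, whether a longer chain, a cyclopropylmethyl group or a chain ending in a hydroxyl group would move the number beyond the scatter at the first position remains open. As far as these compounds go, it is also open whether the change from 3-chlorobenzyl to 3-chlorophenyl keeps its size with 3-methylbut-2-en-1-yl in place of isopentyl, and what a fluorine or a methoxy group in place of the chlorine would do.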